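The source may report more compounds than this note shows. Statements on the series, on what has been measured and on what is new or still open speak of the compounds shown alone.

Series notes. In an ADME assay on the whole organism (Mus musculus, strain BALB/c) for metabolic stability, read by HPLC, with a stated time of 24 h, at a dose of 12.5 mg/kg by the oral route (a lower number here means that the compound disappears faster, a higher number that the compound lasts longer), compound 1 `CC(c1ccc(OC(F)(F)F)cc1)N1CC2(CCN(c3nc(=O)c4cc(C(F)(F)F)cc([N+](=O)[O-])c4s3)CC2)C1` gives 6 h. Compound 3 `CC(c1ccc(C(F)(F)F)cc1)N1CC2(CCN(c3nc(=O)c4cc(C(F)(F)F)cc([N+](=O)[O-])c4s3)CC2)C1` gives 6.69 h and compound 2 `O=c1nc(N2CCN(CC3CCCCC3)CC2)sc2c([N+](=O)[O-])cc(C(F)(F)F)cc12` gives 5.07 h. Among these three numbers compound 1 stands second highest; its nearest neighbour is compound 3 and its furthest is compound 2, and both gaps lie within the scatter, so the three cannot be ordered on this assay. Among the compounds with values here, the only step between measured compounds that differ in one place is a 1.1-fold higher number from compound 1 to compound 3 (0.05 log units; within the scatter), a swap of the group on the same aryl ring that is altered in the compound now in question.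

Compound 4 `CC(c1cc(F)cc(F)c1)N1CC2(CCN(c3nc(=O)c4cc(C(F)(F)F)cc([N+](=O)[O-])c4s3)CC2)C1` has not yet been measured. Its difference from compound 1 is 3,5-difluorophenyl in place of 4-(trifluoromethoxy)phenyl on a saturated chain carbon bound to an amine nitrogen in a ring and a saturated chain carbon. Within the data shown here, no measured step covers this exact change; the step from compound 1 to compound 3, which changes a group on the same ring, produced no movement beyond the scatter, and compound 2, which differs from compound 1 elsewhere, sits in the same band. The expectation for compound 4 is therefore no step beyond the scatter, no change at the digits printed from compound 1 to compound 4 (within the scatter). Compound 4 is expected to give 6 h, with a range from 3.5 h to 10 h.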

Compound 4, half-life: 3.02 h
The estimate for compound 4 lay 2.0-fold (0.30 log units) above the measured number; the whole stated range lies above it.
By their numbers in this assay, from the lowest: compounds 4, 2, 1 and 3 (each within the scatter of the next, the first and the last beyond it).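

In this assay the aryl group on a saturated chain carbon bound to an amine nitrogen in a ring and a saturated chain carbon turns out not to be silent: the change to 3,5-difluorophenyl gives a 2.2-fold lower number from compound 3 to compound 4 (0.35 log units; beyond the scatter) and so clears the scatter, though only modestly, whereas the earlier swap on this ring, a 1.1-fold higher number from compound 1 to compound 3 (0.05 log units; within the scatter), did not. The same change gives a 2.0-fold lower number from compound 1 to compound 4 (0.30 log units; within the scatter) and stays inside the scatter, so the effect at this position rests on one pair and compounds 1 and 4 cannot be ordered on this assay. No measurement on hand bears on why the number moves with this change.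

The compounds shown leave open whether the lower number of compound 4 goes with the two fluorines themselves or simply with the loss of the larger trifluoromethyl or trifluoromethoxy group, which an unsubstituted phenyl ring or a pyridine ring in the same place would help to separate. They also leave open whether a group of another kind on this aryl ring, such as a carboxylic acid or an amine, would move the half-life further in either direction.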